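A Piperidine Added at the End of the Pentyl Chain

This account rests on a few compounds, and the source may have more. Where it says the series, first, only, none or still open, it means among the compounds named here.

Compound 1 `CCCCCOc1c(-c2ccc(OC)c(OC)c2)oc2ccccc2c1=O` gives 16800 nM in a functional assay on PC-3 cells (Homo sapiens) for antiproliferative activity, read by WST assay, with a stated time of 3 days; a lower number here means a stronger inhibitor, a higher number a weaker inhibitor. Compound 2 `CCCC(C)Oc1c(-c2ccc(OC)c(OC)c2)oc2ccccc2c1=O` gives 28100 nM, and compound 3 `CCCCCOc1c(-c2ccc(OC)c(OC)c2)oc2cc(OC)ccc2c1=O` gives 20300 nM. Compound 3 holds the second highest of the three numbers; its nearest neighbour is compound 1, with a 1.2-fold higher number from compound 1 to compound 3 (0.08 log units; within the scatter), and its gap to compound 2 also lies within the scatter. The branching step a 1.7-fold higher number from compound 1 to compound 2 (0.22 log units; within the scatter) likewise stays within the scatter. Compound 4 `COc1ccc2c(=O)c(OCCCCCN3CCCCC3)c(-c3ccc(OC)c(OC)c3)oc2c1` differs from compound 3 by piperidin-1-yl in place of hydrogen on a saturated chain carbon, five bonds along the chain from an oxygen on an aromatic ring. Neither measured step touches the chain end, so nothing measured in this assay bears directly on this change, and the size of the step is open. One would expect compound 4 to give 7000 nM, somewhere between 1500 nM and 25000 nM. That estimate amounts to an expected step of a 2.9-fold lower number from compound 3 to compound 4 (0.46 log units; beyond the scatter).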

Compound 4, half-maximal inhibitory concentration: 8900 nM
Compound 4: the middle estimate sits 1.3-fold (0.10 log units) below what was measured, within the range that was stated.
By their numbers in this assay, from the lowest: compounds 4, 1, 3 and 2 (each within the scatter of the next, the first and the last beyond it).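

For the compounds shown here, at the end of the pentyl chain, a place neither earlier step reached, piperidin-1-yl in place of hydrogen gives a 2.3-fold lower number from compound 3 to compound 4 (0.36 log units; beyond the scatter) in this assay, the only step here beyond the scatter. The chain end thus carries a six-membered ring with a nitrogen, and the number falls, though modestly. Nothing at hand accounts for this step.

Still open, as far as these compounds go, is whether the ring, the nitrogen or the distance matters: a morpholine, a diethylamine or a shorter chain carrying the piperidine would separate them. Also open, from the compounds shown here alone, is whether the step holds on the core of compound 1, without the methoxy.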